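The compounds below may be only part of what the source reports. "The series", "measured", "known", "first", "only" and "open" are said of these compounds alone.

Of the compounds shown here, two from one series have so far been tested in a functional assay on MDA-MB-231 cells (Homo sapiens) for antiproliferative activity, read by MTT assay, with a stated time of 48 h; on this read-out higher numbers stand for weaker inhibition and lower numbers for stronger inhibition. Compound 1 `CCOC(=O)CN(Cc1ccccc1)c1nc(NCc2ccccc2)ncc1[N+](=O)[O-]` gives 82400 nM in this assay. Compound 2 `CCOC(=O)CNc1nc(Nc2ccccc2)ncc1[N+](=O)[O-]` gives 54300 nM in this assay, which puts it at the low end of the two numbers, but its gap to compound 1 lies within the usual scatter, so no order can be read between them. Compound 3 `CCOC(=O)CN(Cc1ccccc1)c1nc(Nc2ccccc2)ncc1[N+](=O)[O-]` has not yet been measured. It differs from compound 2 in a single place: benzyl in place of hydrogen on a nitrogen on an aromatic ring. For the measured compounds named here, no pair of measured compounds isolates this change; compound 1 carries the same benzyl on that nitrogen but differs from compound 3 elsewhere as well, so its value shows only that a compound bearing that group sits in the same weak range. The step from compound 2 to compound 3 is expected to be a 1.1-fold higher number from compound 2 to compound 3 (0.04 log units; within the scatter), nothing beyond the scatter in either direction. Compound 3 is estimated to give about 60000 nM in this assay, with a likely range from 25000 nM to 150000 nM.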

Compound 3, half-maximal inhibitory concentration: > 100000 nM
Compound 3 ended at the assay's limit; the forecaster's own chance of this, stated with the estimate: 10%; middle value at least 1.6-fold (0.22 log units) from the limit.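

In this assay the result for compound 3 is a limit and not a number: the limit of > 100000 nM in this assay, at which 1 of the 3 values shown sits.

For the compounds shown here, for the first time, benzyl in place of hydrogen on a nitrogen on an aromatic ring can be read as a single change, and it gives an at least 1.8-fold higher number from compound 2 to compound 3 (0.26 log units; that floor lies within the scatter), so the change brings no gain in inhibition, while its floor alone does not establish a loss. Phenyl in place of benzyl on a nitrogen on an aromatic ring gives an at least 1.2-fold higher number from compound 1 to compound 3 (0.08 log units; that floor lies within the scatter), so this second change also shows no gain in inhibition.

From the compounds shown here alone, the true size of both steps stays open, since compound 3 has only a limit. Also open, going by these compounds, is whether a methyl group or an aminoethyl chain on that nitrogen, or a carboxylic acid in place of the ethyl ester, would change the read-out.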